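The source may report more compounds than this note shows. Statements on the series, on what has been measured and on what is new or still open speak of the compounds shown alone.

Of the compounds shown here, three have so far been measured in an ADME assay on microsomes from liver (Homo sapiens) for metabolic stability, with a stated time of 30 min, tested at 1 uM; on this read-out higher numbers stand for a more stable compound and lower numbers for a less stable compound. Compound 1 `CCN1CCN(c2ccc(Nc3ncc4c(n3)N(C)C(=O)N(c3cc(NC(=O)c5cccc(C(F)(F)F)c5)ccc3C)C4)cc2)CC1` gives 46.7%, compound 2 `Cc1ccc(NC(=O)c2cccc(C(F)(F)F)c2)cc1N1Cc2cnc(Nc3cnn(C)c3)nc2N(C)C1=O` gives 78.8%, and compound 3 `CCN1CCN(c2ccc(Nc3ncc4c(n3)N(C)C(=O)N(c3cc(NC(=O)c5cccc(C(F)(F)F)c5)ccc3C)C4)cn2)CC1` gives 29.8%. Compound 2 therefore stands highest of the three: its number lies beyond the scatter above that of compound 1, and further still above that of compound 3.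

Compound 4 `Cc1cc(Nc2ncc3c(n2)N(C)C(=O)N(c2cc(NC(=O)c4cccc(C(F)(F)F)c4)ccc2C)C3)n(C)n1` has not yet been measured in this assay. It differs from compound 2 in one place: 1,3-dimethyl-1H-pyrazol-5-yl in place of 1-methyl-1H-pyrazol-4-yl on a nitrogen on an aromatic ring. The ring stays five-membered with two hetero atoms, and the counts of hydrogen-bond donors and acceptors do not change. Going by the values given here, no measured pair shows this exact change, so there is no comparable step to lean on. The step is expected to be modestly downward, a number 13.8 percentage points lower from compound 2 to compound 4 (beyond the scatter), and it may well fall within the scatter. On that basis compound 4 is expected to give about 65% in this assay, most likely between 40% and 88%.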

Compound 4, percent of the compound remaining: 69.2%
Estimate against measurement, compound 4: 4.2 percentage points below; the range from low to high includes it.
By their numbers in this assay, from the lowest: compound 3; then compound 1; then compounds 4 and 2 (each within the scatter of the next).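

In this assay, replacing 1-methyl-1H-pyrazol-4-yl with 1,3-dimethyl-1H-pyrazol-5-yl on this nitrogen gives a number 9.6 percentage points lower from compound 2 to compound 4 (within the scatter), so the read-out does not separate compound 2 from compound 4. At this position, then, the ring can carry one more methyl group and attach through a different ring carbon without a change that exceeds the usual scatter. Nothing available bears on why the two groups read alike.

This single step changes both features at once, so 1-methyl-1H-pyrazol-5-yl would be needed to show what each contributes on its own. The compounds shown also leave open how this position would respond to a group outside the pyrazoles, such as a morpholine or a carboxylic acid.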